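This account rests on a few compounds, and the source may have more. Where it says the series, first, only, none or still open, it means among the compounds named here.

Measured so far:
compound 1 `CCOC(=O)c1c(C)nc(-c2cccc(C#N)c2)n1OC` — in a functional assay on a cell-free system (plasma, Oryctolagus cuniculus) for inhibition, with stated times of 5 min, 1 min and 6 min (on this read-out lower numbers stand for stronger inhibition and higher numbers for weaker inhibition), compound 1 gives 9130 nM
compound 2 `CCOC(=O)c1c(C)nc(-c2cccc(C#N)c2)n1OCc1ccccc1Cl` — in this assay compound 2 gives 8710 nM

Compound 2 and compound 1 lie within the scatter of each other; the step of a 1.0-fold lower number from compound 1 to compound 2 (0.02 log units; within the scatter) does not separate them, so neither can be called the stronger inhibitor.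

Compound 3 `CCOC(=O)c1c(C)nc(-c2cccc(C#N)c2)n1OCc1ccccc1C#N` differs from compound 2 by cyano in place of chloro on an aromatic carbon. Among the compounds with values here, no measured step probes this exchange. Within the data shown here, the only step in hand, a 1.0-fold lower number from compound 1 to compound 2 (0.02 log units; within the scatter), concerns a different place, where the whole 2-chlorophenyl enters, and it stayed within the scatter; it says nothing about cyano against chloro. With no guide, the expectation for compound 3 is a step of a 1.0-fold higher number from compound 2 to compound 3 (0.01 log units; within the scatter), that is, none beyond the scatter, with the range widened for the missing precedent. Compound 3 is thus estimated at 9000 nM, expected between 4000 nM and 20000 nM.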

Compound 3, half-maximal inhibitory concentration: 9380 nM
Beside the measured number, compound 3's estimate is 1.0-fold (0.02 log units) below it; the measured number falls inside the stated range.
By their numbers in this assay, from the lowest: compounds 2, 1 and 3 (each within the scatter of the next).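

At the aromatic carbon ortho to a large group, cyano in place of chloro gives a 1.1-fold higher number from compound 2 to compound 3 (0.03 log units; within the scatter) in this assay, so this exchange does not separate the two groups at this position. With 2-cyanophenyl in place of hydrogen on the saturated chain carbon bound to an oxygen on an aromatic ring, the reading is a 1.0-fold higher number from compound 1 to compound 3 (0.01 log units; within the scatter), so a second ortho-substituted phenyl group at this carbon also stays within the scatter of compound 1. No independent evidence accompanies these readings.

From the compounds shown here alone, what an amine or a carboxylic acid would give at this aromatic carbon remains open. Also open, going by these compounds, is whether a longer chain between the oxygen and the phenyl ring would give a step beyond the scatter.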